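A few compounds are considered here, and "the series" means these few. Any claim that something is new, unique, unknown or untested is made for them only; others in the source may bear on it.

Compound 1 `CC(C)CNc1nc(N)nc2c1ncn2/C=C1/CC1(CO)CO`: in an ADME assay on Akata cells (Homo sapiens) for cytotoxicity, with a stated time of 7 days (on this read-out lower numbers stand for higher toxicity in this test and higher numbers for lower toxicity in this test), compound 1 gives > 24000 nM, a limit of the assay rather than a number.
Compound 2 `CCCCCCCCSc1nc(N)nc2c1ncn2/C=C1/CC1(CO)CO`: in this assay compound 2 gives > 20000 nM, again a limit.
Compound 3 `COCCOc1nc(N)nc2c1ncn2/C=C1/CC1(CO)CO`: in this assay compound 3 gives > 20000 nM, also a limit.

Compound 3 therefore stands only at a limit in this assay, and the other two values in the set are limits as well (the limit of > 20000 nM in this assay, at which 2 of the 3 values shown sit, (the limit of > 24000 nM in this assay, at which 1 of the 3 values shown sits)), so no compound is separated from any other on the numbers shown.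

Compound 4 `Nc1nc(OCc2ccccc2)c2ncn(/C=C3/CC3(CO)CO)c2n1` differs from compound 3 by phenyl in place of methoxymethyl on a saturated chain carbon bound to an oxygen on an aromatic ring. The steps that end at compound 3, a step that the two limits leave unreadable from compound 1 to compound 3 and a step that the two limits leave unreadable from compound 2 to compound 3, are left unreadable by the limits, and a step that the two limits leave unreadable from compound 1 to compound 2 is unreadable in the same way; none of them gives a size or a direction. Going by the values given here, no measured step touches the exchange of methoxymethyl for phenyl on the saturated chain carbon bound to the oxygen on the aromatic ring.

With every value in the set at a limit, the step of a number no higher from compound 3 to compound 4 (the limit leaves the size open) expected for compound 4 is none beyond the scatter, most likely returned as a limit once more. Compound 4 is estimated at 20000 nM, with a range from 8000 nM to 50000 nM.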

Compound 4, half-maximal cytotoxic concentration: > 20000 nM
Compound 4: a limit, no number; the forecaster's own chance of this, stated with the estimate: 80%; the middle value lies on the limit itself.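

In this assay compound 4 gives > 20000 nM, a limit and not a number, so its steps from compound 1, compound 2 and compound 3 cannot be read. The compounds shown leave open whether any exchange on this aromatic carbon alters cytotoxicity at all.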